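Swapping the imidazole thioether for a benzoxazole

This account rests on a few compounds, and the source may have more. Where it says the series, first, only, none or still open, it means among the compounds named here.

Compound 1, `CC(C)[C@H](NC(=O)COc1cccc2ccccc12)C(=O)N[C@@H](CC(=O)O)C(=O)CSc1nccn1C`, is a peptide-like ketone that was tested in a functional assay on Jurkat cells (Homo sapiens) for inhibition; on this read-out lower numbers stand for stronger inhibition and higher numbers for weaker inhibition. In this assay compound 1 gives only a limit, > 200000 nM, and not a number. Among the compounds with values here, its one measured neighbour is compound 2, `CC(C)[C@H](NC(=O)COc1cccc2ccccc12)C(=O)N[C@@H](CC(=O)O)C(=O)CSc1nc(-c2ccccc2)cs1`, which carries 4-phenyl-1,3-thiazol-2-yl in place of 1-methyl-1H-imidazol-2-yl on a sulfur. In this assay compound 2 likewise gives only a limit, > 200000 nM. The step that the two limits leave unreadable from compound 1 to compound 2 therefore cannot be read, because of the limit of > 200000 nM in this assay, at which 2 of the 2 values shown sit.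

Compound 3, `CC(C)[C@H](NC(=O)COc1cccc2ccccc12)C(=O)N[C@@H](CC(=O)O)C(=O)CSc1nc2ccccc2o1`, is not yet measured. It differs from compound 1 as follows: 1,3-benzoxazol-2-yl in place of 1-methyl-1H-imidazol-2-yl on a sulfur. Within the data shown here, this is a change at the same sulfur as the only measured step, but that step is unreadable, so nothing about its size or direction can be taken from it. Both measured values sit at the limit, so the expectation for compound 3 is that it stays there as well. Compound 3 is therefore expected to give about 200000 nM, within an estimated range from 50000 nM to 1000000 nM. The expected step of a number no higher from compound 1 to compound 3 (the limit leaves the size open) is an estimate of no readable change.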

Compound 3, half-maximal inhibitory concentration: > 200000 nM
Compound 3: no number, only a limit; the forecaster's own chance of this, stated with the estimate: 70%; the middle value lies on the limit itself.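

In this assay compound 3 gives > 200000 nM, which is a limit and not a number. The steps to compound 3 from compound 1 and from compound 2 cannot be read, because all three values stop at the same point: the limit of > 200000 nM in this assay, at which 3 of the 3 values shown sit. The compounds shown leave open whether any group on this sulfur gives a measurable inhibition, and how large it would be.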